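Chloro for methyl on a scaffold without measured toxicity

The compounds below may be only part of what the source reports. "The series", "measured", "known", "first", "only" and "open" are said of these compounds alone.

Compound 1 `Cc1ccccc1C(=O)Nc1ncc(-c2ccccc2)n1C` gives > 100000 nM in a toxicity assay on THP-1 cells (Homo sapiens) for inhibition (on this read-out lower numbers stand for higher toxicity in this test and higher numbers for lower toxicity in this test), a limit of the assay.
Compound 2 `COc1ccc(-c2cnc(NC(=O)c3ccccc3C)n2C)cc1` gives > 100000 nM in this assay, again a limit.
Compound 3 `COc1ccc(CNC(=O)NC(=O)c2ccc(F)cc2)cc1` gives > 50000 nM in this assay, also a limit.

Going by the values given here, the only step between measured compounds, a step that the two limits leave unreadable from compound 1 to compound 2, cannot be sized because both ends sit at the limit of > 100000 nM in this assay, at which 2 of the 3 values shown sit. Compound 2 therefore stands at a limit and not at a number; the remaining value sits at the limit of > 50000 nM in this assay, at which 1 of the 3 values shown sits. Compound 4 `COc1ccc(-c2cnc(NC(=O)c3ccccc3Cl)n2C)cc1` differs from compound 2 in this way: chloro in place of methyl on an aromatic carbon. Among the compounds with values here, no measured step bears on this change, so nothing beyond the scatter is expected in this assay. Compound 4 is expected to stay at the limit, an expected step of a number no higher from compound 2 to compound 4 (the limit leaves the size open), with an estimate of 100000 nM between 50000 nM and 200000 nM.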

Compound 4, half-maximal cytotoxic concentration: > 50000 nM
Compound 4: no number, only a limit (the forecaster's own chance of this, stated with the estimate: 85%); the middle value is on the limit's open side.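

Compound 2 gives > 100000 nM in this assay, a limit. Compound 4 gives > 50000 nM, also a limit. Going by these compounds alone, no step can therefore be read between compound 2 and compound 4. The compounds shown leave open whether chloro in place of methyl alters the half-maximal cytotoxic concentration in this assay at all.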